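Methyl on the pyridin-3-yl group of compound 1

The compounds below may be only part of what the source reports. "The series", "measured", "known", "first", "only" and "open" are said of these compounds alone.

Compound 1 `CCC(CC)CNc1c(C(N)=O)cnc2ccc(-c3cccnc3)cc12` carries a 2-ethylbutyl group on the ring nitrogen and a pyridin-3-yl group on the shared core. In an assay on HT-29 cells for inhibition of Serine-protein kinase ATM (Homo sapiens), read by fluorescence, with a stated time of 1 h (on this read-out higher numbers stand for weaker inhibition and lower numbers for stronger inhibition), compound 1 gives 73 nM, the lowest of the two numbers measured, although its gap to compound 2 is within the scatter. Compound 2 `NC(=O)c1cnc2ccc(-c3cccnc3)cc2c1NC1CCCCC1` differs only at the nitrogen substituent. In this assay compound 2 gives 132 nM. The step of a 1.8-fold higher number from compound 1 to compound 2 (0.26 log units; within the scatter) shows that exchanging the chain for a ring at that nitrogen moves the number little.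

Compound 3 `CCC(CC)CNc1c(C(N)=O)cnc2ccc(-c3ccc(C)nc3)cc12` differs from compound 1 elsewhere: methyl in place of hydrogen on an aromatic carbon. For the measured compounds named here, no measured step touches the pyridin-3-yl group; the only step recorded, a 1.8-fold higher number from compound 1 to compound 2 (0.26 log units; within the scatter), concerns the nitrogen substituent and does not bear on a change at the pyridin-3-yl group. With nothing to indicate a shift in this assay in either direction, the expected step of a 1.0-fold higher number from compound 1 to compound 3 (0.01 log units; within the scatter) is none beyond the scatter. Compound 3 is therefore estimated at 75 nM in this assay, with a range from 25 nM to 220 nM.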

Compound 3, half-maximal inhibitory concentration: 50 nM
The estimate for compound 3 lay 1.5-fold (0.18 log units) above the measured number; the measured number falls inside the stated range.
By their numbers in this assay, from the lowest: compounds 3, 1 and 2 (each within the scatter of the next, the first and the last beyond it).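

In this assay, for the compounds shown here, the methyl on the aromatic carbon next to the ring nitrogen and para to a large group is the first measured change on the pyridin-3-yl group. The change to 6-methylpyridin-3-yl gives a 1.5-fold lower number from compound 1 to compound 3 (0.16 log units; within the scatter) and so shows that this position accepts a methyl with no shift that can be told apart from repeat variation. The series now has one measured change at each of two places, the nitrogen substituent and this ring carbon, and neither step lies beyond the scatter; no available evidence explains the result at this position.

The compounds shown carry only hydrogen or methyl at this carbon, so it remains open whether a methoxy group, an amine or a trifluoromethyl group there would give a step beyond the scatter. Also open, as far as these compounds go, are the effect of a methyl on the other carbons of the pyridin-3-yl group and whether the 6-methylpyridin-3-yl group would give a similar step alongside the cyclohexyl group of compound 2.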